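Phenyl for Ethyl on the Shared Core Nitrogen

This account rests on a few compounds, and the source may have more. Where it says the series, first, only, none or still open, it means among the compounds named here.

Compound 1 `C=CCn1c(SCC(=O)c2ccccc2)nnc1-c1ccccc1`: 58%
Compound 2 `CCn1c(SCC(=O)c2ccccc2)nnc1-c1ccccc1`: 55%

In a functional assay on the whole organism (strain albino) for inhibition, with Rattus norvegicus as the target, read by paw edema, with a stated time of 2 h, at a dose of 0.28 mmol/kg by the oral route (a higher number here means more inhibition at the dose given (going by the name of the read-out), a lower number less inhibition), compound 2 gives 55%, and compound 1 gives 58%, the two numbers lying within the scatter of each other. For the measured compounds named here, the one measured step, a number 3 percentage points lower from compound 1 to compound 2 (within the scatter), also changed the group on this ring nitrogen and stayed within the scatter. Compound 3 `O=C(CSc1nnc(-c2ccccc2)n1-c1ccccc1)c1ccccc1` differs from compound 2 by phenyl in place of ethyl on an aromatic nitrogen. Because the step of a number 3 percentage points lower from compound 1 to compound 2 (within the scatter) was small, the step to compound 3 is expected to be small as well, a number 3 percentage points lower from compound 2 to compound 3 (within the scatter). Compound 3 is estimated at 52%, between 35% and 70%.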

Compound 3, a percentage reported as inhibition, in the whole organism at one dose (the size of the read-out at that dose, not a potency): 60%
The estimate for compound 3 lay 8 percentage points below the measured number; measured number inside the range.
By their numbers in this assay, from the lowest: compounds 2, 1 and 3 (each within the scatter of the next).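

In this assay the aromatic nitrogen of the shared core carries a ring as well as a chain: phenyl in place of ethyl gives a number 5 percentage points higher from compound 2 to compound 3 (within the scatter) and phenyl in place of allyl gives a number 2 percentage points higher from compound 1 to compound 3 (within the scatter). The larger group, with 6 heavy atoms against 2 for ethyl, thus stays within the scatter of both chains at this position. Nothing at hand bears on why these numbers lie so close. On these data alone, whether an amine, a carboxylic acid or a longer chain on this nitrogen would stay within that scatter remains open. So does the effect of a chlorine or a methoxy group on the entering phenyl.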